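This account rests on a few compounds, and the source may have more. Where it says the series, first, only, none or still open, it means among the compounds named here.

The study measured two compounds in a functional assay on PC-3 cells (Homo sapiens) for antiproliferative activity, read by XTT assay; a higher number here means a weaker inhibitor, a lower number a stronger inhibitor. Compound 1 `COc1cccc2occ(Cc3coc4ccccc4c3=O)c(=O)c12` gave 3490 nM, and compound 2 `O=c1c(Cc2coc3cccc(OCC4CCCCC4)c3c2=O)coc2ccccc12` gave 4510 nM. Within the data shown here, the single step that links them is a 1.3-fold higher number from compound 1 to compound 2 (0.11 log units; within the scatter). Compound 2 thus carries the higher of the two numbers, with compound 1 its nearest neighbour, but the gap between them stays within the scatter, so no order between the two can be read from it.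

Compound 3 `O=c1c(Cc2coc3cccc(OCC4CCCCC4)c3c2=O)coc2cc(O)ccc12` has not yet been measured in this assay. It differs from compound 2 by hydroxy in place of hydrogen on an aromatic carbon. No measured step concerns a hydroxy group entering an aromatic carbon, so none of the numbers shown bears directly on this change. Among the measured compounds shown here, the only step available, a 1.3-fold higher number from compound 1 to compound 2 (0.11 log units; within the scatter), touches a different part of the molecule and fell within the scatter, which gives no reason to expect a large move in either direction. A step within the scatter is therefore expected: a 1.1-fold lower number from compound 2 to compound 3 (0.05 log units; within the scatter). Compound 3 is estimated to give 4000 nM in this assay, within a range of 1500 nM to 11000 nM.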

Compound 3, half-maximal inhibitory concentration: 4250 nM
Compound 3: middle estimate off by 1.1-fold (0.03 log units), on the low side; measured number inside the range.
By their numbers in this assay, from the lowest: compounds 1, 3 and 2 (each within the scatter of the next).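

Hydroxy in place of hydrogen on an aromatic carbon appears in this assay as a 1.1-fold lower number from compound 2 to compound 3 (0.03 log units; within the scatter), so at this position, on a six-membered aromatic ring of carbon only, meta to a fused ring and para to a fused ring, the change leaves no readable mark on the number. This is the first look at that ring carbon, since the earlier step from cyclohexyl in place of hydrogen concerned a different part of the molecule, and now both single changes shown stay within the scatter. No measurement at hand bears on why the entering hydroxy, with its hydrogen-bond donor and acceptor, leaves the number where it stands.

On these data alone, it remains open whether an amine, a carboxylic acid or a fluorine atom on this same aromatic carbon would also stay within the scatter, or whether hydroxy would do so on another carbon of that ring. Also open, as far as these compounds go, is whether hydroxy at this position would read the same on the core of compound 1, without the cyclohexyl group.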